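Thromboxane synthase series: aryloxy substitution on the shared core

The source may hold more compounds than are shown below. What is called first, only, known or untested is meant among the compounds shown, and "the series" means these compounds.

Measured compounds:
compound 1, `O=C(O)CC/C=C\CC1COC(c2cccs2)OC1c1cccnc1`: 71 nM
compound 2, `CC(C)(Oc1ccccc1)C1OCC(C/C=C\CCC(=O)O)C(c2cccnc2)O1`: 52 nM
compound 3, `CC(C)(Oc1ccccc1Br)C1OCC(C/C=C\CCC(=O)O)C(c2cccnc2)O1`: 29 nM

In an assay for inhibition of Thromboxane-A synthase (Homo sapiens), using microsomes (on this read-out lower numbers stand for stronger inhibition and higher numbers for weaker inhibition), compound 2 gives 52 nM, the second highest of the three numbers; compound 1 sits nearest and compound 3 furthest, both within the scatter of compound 2. The step of a 1.4-fold lower number from compound 1 to compound 2 (0.14 log units; within the scatter) exchanged the thienyl group on the shared core for the phenoxy-bearing group; the step of a 1.8-fold lower number from compound 2 to compound 3 (0.25 log units; within the scatter) added bromo on an aromatic carbon. Neither step moved the number beyond the scatter.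

Compound 4, `CC(C)(Oc1ccc(F)cc1[N+](=O)[O-])C1OCC(C/C=C\CCC(=O)O)C(c2cccnc2)O1`, is not yet measured in this assay. It differs from compound 2 by 4-fluoro-2-nitrophenyl in place of phenyl on an oxygen on a saturated carbon. Going by the values given here, of the measured steps only the one from compound 2 to compound 3 bears on this change, since it also alters the phenyl of the aryloxy group, and it was small. A step of similar size and direction, or none beyond the scatter, is therefore expected: a 1.3-fold lower number from compound 2 to compound 4 (0.11 log units; within the scatter). Compound 4 is estimated at 40 nM, within a range of 15 nM to 120 nM.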

Compound 4, half-maximal inhibitory concentration: 20 nM
The estimate for compound 4 lay 2.0-fold (0.30 log units) above the measured number; measured number inside the range.
By their numbers in this assay, from the lowest: compounds 4, 3, 2 and 1 (each within the scatter of the next, the first and the last beyond it).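

In this assay, the aryl group on this oxygen can move the number beyond the scatter: 4-fluoro-2-nitrophenyl in place of phenyl gives a 2.6-fold lower number from compound 2 to compound 4 (0.41 log units; beyond the scatter), the only step shown between compounds differing in one place that lies beyond it. The two substituted aryl groups are not separated, since 4-fluoro-2-nitrophenyl in place of 2-bromophenyl gives a 1.5-fold lower number from compound 3 to compound 4 (0.16 log units; within the scatter), which is within the scatter. No supporting data bear on this result.

Fluoro and nitro enter together in compound 4, so their separate contributions to the step remain open. Also open, from the compounds shown here alone, is whether 4-fluorophenyl, 2-nitrophenyl or 2-aminophenyl on the same oxygen would hold the number of compound 4.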